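Adding a Methoxy Group to Compound 2

A few compounds are considered here, and "the series" means these few. Any claim that something is new, unique, unknown or untested is made for them only; others in the source may bear on it.

In a functional assay on MCF7 cells (Homo sapiens) for antiproliferative activity, read by resazurin assay, with a stated time of 48 h (a lower number here means a stronger inhibitor, a higher number a weaker inhibitor), compound 1 (`COc1cccc(/C=C/C(=O)N2CCC=CC2=O)c1`) gives 7500 nM and compound 2 (`COc1ccc(/C=C/C(=O)N2CCC=CC2=O)cc1`) gives 8200 nM with the two values within the scatter of each other. Compound 3 (`COc1ccc(/C=C/C(=O)N2CCC=CC2=O)cc1OC`) differs from compound 2 by methoxy in place of hydrogen on an aromatic carbon, ortho to a methoxy group and meta to a large group. Among the compounds with values here, no measured pair shows this change, so only a small move toward a lower number, none beyond the scatter, is expected in this assay for this compound. The expected step of a 1.3-fold lower number from compound 2 to compound 3 (0.10 log units; within the scatter) stays within the scatter. Compound 3 is estimated at 6500 nM (expected range 3000 nM to 13000 nM).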

Compound 3, half-maximal inhibitory concentration: 3700 nM
The estimate for compound 3 lay 1.8-fold (0.24 log units) above the measured number; the range from low to high includes it.
By their numbers in this assay, from the lowest: compound 3; then compounds 1 and 2 (each within the scatter of the next).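

In this assay the methoxy group in place of hydrogen, ortho to a methoxy group and meta to a large group, gives a 2.2-fold lower number from compound 2 to compound 3 (0.35 log units; beyond the scatter) and also a 2.0-fold lower number from compound 1 to compound 3 (0.31 log units; beyond the scatter) in a modest move beyond the scatter. Compound 1 and compound 2 each carry one methoxy group and lie within the scatter of each other, whereas compound 3 with two stands apart from both. Nothing given here accounts for this step.

The compounds shown leave open whether a hydroxy group or an amine on this aromatic carbon would give a step of similar size. They also leave open whether a third methoxy group on the ring would lower the number further.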